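Chloro to Methyl on the Aryl Amide of the Shared Core

The compounds below may be only part of what the source reports. "The series", "measured", "known", "first", "only" and "open" are said of these compounds alone.

Measured compounds in an assay on HEK293 cells for positive allosteric modulation of metabotropic glutamate receptor 5 (Homo sapiens), read by FLIPR; on this read-out higher numbers stand for an effect only at larger amounts of compound and lower numbers for an effect already at smaller amounts:
compound 1, `O=C(c1ccc(F)c(F)c1)N1CC(c2nc(-c3cccc(F)c3)no2)C1`, gives 3200 nM
compound 2, `O=C([C@H]1CC2CCC1C2)N1CC(c2nc(-c3cccc(F)c3)no2)C1`, gives 72 nM
compound 3, `O=C(c1ccc(Cl)cc1)N1CC(c2nc(-c3cccc(F)c3)no2)C1`, gives 2500 nM

Compound 3 sits second highest of the three numbers in this assay. Its nearest neighbour is compound 1, and that pair lies within the scatter: a 1.3-fold lower number from compound 1 to compound 3 (0.11 log units; within the scatter). Compound 2 stands far apart from both: a 35-fold higher number from compound 2 to compound 3 (1.54 log units; beyond the scatter) and a 44-fold lower number from compound 1 to compound 2 (1.65 log units; beyond the scatter).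

Compound 4, `Cc1ccc(C(=O)N2CC(c3nc(-c4cccc(F)c4)no3)C2)cc1`, differs from compound 3 in one place: methyl in place of chloro on an aromatic carbon. Among the compounds with values here, the one measured step that bears on it is the aryl-to-aryl exchange on the carbonyl carbon, a 1.3-fold lower number from compound 1 to compound 3 (0.11 log units; within the scatter), which stayed within the scatter; the large steps both involve the bicyclic group of compound 2 and say nothing about a change within an aryl ring. The expectation for compound 4 in this assay is therefore no step beyond the scatter, no change at the digits printed from compound 3 to compound 4 (within the scatter), in either direction. Compound 4 is estimated at 2500 nM, with a range from 1000 nM to 6500 nM.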

Compound 4, half-maximal effective concentration: 6800 nM
For compound 4 the middle estimate is 2.7-fold (0.43 log units) below the measured one; the whole stated range lies below it.
By their numbers in this assay, from the lowest: compound 2; then compounds 3 and 1 (each within the scatter of the next); then compound 4.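

In this assay, the change from 4-chlorophenyl to 4-methylphenyl gives a modest step beyond the scatter (a 2.7-fold higher number from compound 3 to compound 4 (0.43 log units; beyond the scatter)), so this place, para to a large group, does respond to the exchange of one heavy atom for another, although the earlier aryl-to-aryl comparison had stayed within the scatter. Compound 4 also separates from the other aryl amide (a 2.1-fold higher number from compound 1 to compound 4 (0.33 log units; beyond the scatter)), and its distance from the non-aromatic group of compound 2 is large (a 94-fold higher number from compound 2 to compound 4 (1.98 log units; beyond the scatter)). Nothing shown here accounts for the difference between methyl and chloro at this place. As far as these compounds go, it remains open how other groups on this aromatic carbon, such as methoxy, trifluoromethyl or an amine, would stand against chloro and methyl. From the compounds shown here alone, it is also open whether the same exchange would give a similar step on a different core.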